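A few compounds are considered here, and "the series" means these few. Any claim that something is new, unique, unknown or untested is made for them only; others in the source may bear on it.

Measured so far in an assay on isolated protein for inhibition of Dihydrofolate reductase (Mus musculus), at pH 7.20; on this read-out lower numbers stand for lower potency and higher numbers for higher potency (the scale is a negative logarithm):
compound 1, `CC1(C)N=C(N)N=C(N)N1c1ccccc1N`, 3.41
compound 2, `CC1(C)N=C(N)N=C(N)N1c1ccccc1S`, 6.86
compound 3, `CC1(C)N=C(N)N=C(N)N1c1ccccc1O`, 2.92

Compound 3 stands lowest of the three. Its nearest neighbour is compound 1, reached by a number 0.49 log units lower from compound 1 to compound 3 (beyond the scatter); its furthest is compound 2, which lies a number 3.94 log units lower from compound 2 to compound 3 (beyond the scatter) above it. The step to compound 4, `CC1(C)N=C(N)N=C(N)N1c1ccccc1I`, changes the same position: iodo in place of hydroxy on an aromatic carbon. Two of the measured steps bear on this position. The exchange of amino for sulfanyl gave a number 3.45 log units higher from compound 1 to compound 2 (beyond the scatter), a large gain, while the exchange of amino for hydroxy gave only the modest a number 0.49 log units lower from compound 1 to compound 3 (beyond the scatter). Both show that this position tolerates wide swings, and that the hydroxy group sits at the bottom of the series. Going by these compounds, a group with neither donor nor acceptor, such as iodo, is therefore expected to lift this assay well above compound 3, though how far remains open, since no halogen has been measured here. The step from compound 3 to compound 4 is estimated at a number 2.38 log units higher from compound 3 to compound 4 (beyond the scatter), a rise beyond the scatter. Compound 4 is thus expected to give about 5.3 in this assay, within 3.8 to 6.8.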

Compound 4, logarithm of the reciprocal of the active concentration, log(1/C): 2.49
Compound 4: the middle estimate sits 2.81 log units above what was measured; the whole stated range lies above it.
By their numbers in this assay, from the lowest: compound 4; then compound 3; then compound 1; then compound 2.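

In this assay, the exchange of hydroxy for iodo, which carries no hydrogen-bond donor or acceptor, gives no rise at this position (a number 0.43 log units lower from compound 3 to compound 4 (beyond the scatter)), and iodo also falls short of amino (a number 0.92 log units lower from compound 1 to compound 4 (beyond the scatter)), so the absence of donor and acceptor does not by itself bring a high number here. Going by these compounds alone, the gap to sulfanyl is large (a number 4.37 log units lower from compound 2 to compound 4 (beyond the scatter)), which leaves sulfanyl as the only one of the four groups with a high number, while amino, hydroxy and iodo differ from one another only modestly. Nothing available here explains why sulfanyl differs so sharply from the other three groups.

Going by these compounds, whether the high number is confined to sulfanyl or extends to related groups such as methylsulfanyl remains open. On these data alone, how a smaller halogen such as chloro or fluoro would compare with iodo on this aromatic carbon also remains open.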